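A Bulkier Amide Group in Place of Morpholine

The source may report more compounds than this note shows. Statements on the series, on what has been measured and on what is new or still open speak of the compounds shown alone.

Compound 1 `COc1cc(N2CCN(C(=O)C3CCC(O)CC3)CC2)ccc1Nc1nc(NC2CCCCC2)c2nc[nH]c2n1` and compound 2 `COc1cc(N2CCC(C(=O)N3CCOCC3)CC2)ccc1Nc1nc(NC2CCCCC2)c2nc[nH]c2n1` have the same core but carry different side chains. In an ADME assay for permeability, using PAMPA (on this read-out higher numbers stand for higher permeability and lower numbers for lower permeability), compound 1 gives 81 10^-6 cm/s and compound 2 gives 744 10^-6 cm/s. Compound 2 therefore holds the higher of the two numbers, and its gap to compound 1 lies beyond the usual scatter.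

Compound 3 `COc1cc(N2CCC(CC(=O)N3CCC(N(C)C)C3)CC2)ccc1Nc1nc(NC2CCCCC2)c2nc[nH]c2n1` differs from compound 2 in one place: ((3-(dimethylamino)pyrrolidin-1-yl)carbonyl)methyl in place of (morpholin-4-yl)carbonyl on a saturated ring carbon. In short, ((3-(dimethylamino)pyrrolidin-1-yl)carbonyl)methyl stands in place of (morpholin-4-yl)carbonyl on a saturated ring carbon. Within the data shown here, no measured pair shows this exchange, so the forecast is uncertain. Compound 2 sits at the top of a very small set, so a drop beyond the scatter is expected. The estimated change is a 3.7-fold lower number from compound 2 to compound 3 (0.57 log units; beyond the scatter). In this assay, compound 3 is expected at 200 10^-6 cm/s, with an estimated range of 40 10^-6 cm/s to 700 10^-6 cm/s.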

Compound 3, apparent permeability: "impermeable" (no number reported)
The entry for compound 3 holds no number; there is nothing to compare the estimate with.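

In this assay, among these compounds, compound 3 is recorded only as "impermeable", with no number, so no step from compound 2 can be read. As far as these compounds go, the size of the change between compound 2 and compound 3 stays open, and no measured evidence bears on this result.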